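The compounds below may be only part of what the source reports. "The series", "measured", "known", "first", "only" and "open" are said of these compounds alone.

In a functional assay on A549 cells (Homo sapiens) for antiproliferative activity, read by MTT assay, with a stated time of 48 h; a higher number here means a weaker inhibitor of growth, a lower number a stronger inhibitor of growth:
- compound 1 `Cc1ccc(-c2cnc(N(Cc3ccc(C(=O)NO)cc3)CC(C)C)s2)cc1`: 20400 nM
- compound 2 `CCCCCCCCN(Cc1ccc(C(=O)NO)cc1)c1ncc(-c2ccc(C)cc2)s1`: 4630 nM
- compound 3 `Cc1ccc(OCCCN(Cc2ccc(C(=O)NO)cc2)c2ncc(-c3ccc(C)cc3)s2)cc1`: 32500 nM

Among the measured compounds shown here, compound 3 sits well apart from only one neighbour: a 7.0-fold higher number from compound 2 to compound 3 (0.85 log units; beyond the scatter). The other gap, a 1.6-fold higher number from compound 1 to compound 3 (0.20 log units; within the scatter), stays within the scatter.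

Compound 4 `Cc1ccc(-c2cnc(N(Cc3ccc(C(=O)NO)cc3)C(C)C)s2)cc1` has isopropyl in place of 3-(4-methylphenoxy)propyl on a nitrogen on an aromatic ring. For the measured compounds named here, the closest precedent is compound 1, which carries isopropyl on a saturated chain carbon and reads 20400 nM. The gain seen in a 4.4-fold lower number from compound 1 to compound 2 (0.64 log units; beyond the scatter) came with heptyl, a group absent here, so it offers little support for a drop. In this assay, the expected change is a 1.5-fold lower number from compound 3 to compound 4 (0.17 log units; within the scatter), with none expected beyond the scatter. The estimate for compound 4 is 22000 nM, with an expected range of 9000 nM to 50000 nM.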

Compound 4, concentration for 50% growth inhibition: 3830 nM
Compound 4: the middle estimate sits 5.7-fold (0.76 log units) above what was measured; the measured number lies below the stated range.
By their numbers in this assay, from the lowest: compounds 4 and 2 (each within the scatter of the next); then compounds 1 and 3 (each within the scatter of the next).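

In this assay the substituent on this nitrogen does not follow chain length: isopropyl and octyl read alike (a 1.2-fold lower number from compound 2 to compound 4 (0.08 log units; within the scatter)), while isopropyl in place of isobutyl alone moves the number (a 5.3-fold lower number from compound 1 to compound 4 (0.73 log units; beyond the scatter)). Isopropyl in place of 3-(4-methylphenoxy)propyl gives a step of similar scale (an 8.5-fold lower number from compound 3 to compound 4 (0.93 log units; beyond the scatter)), so compound 1 and compound 3 read high despite very different chains. Nothing available accounts for this sensitivity.

On these data alone, whether a cyclopropyl, or a chain ending in an amine or a carboxylic acid, would read with compound 4 or with compound 1 stays open.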